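The source may hold more compounds than are shown below. What is called first, only, known or untested is meant among the compounds shown, and "the series" means these compounds.

Measured compounds:
compound 1 `Cc1cc(C)c(CN2CCc3c(Cl)cc([C@@H](CO)[C@@H]4CCCO4)c(Cl)c3C2=O)c(=O)[nH]1`: 70.3 uL/min
compound 2 `COC(c1cc(Cl)c2c(c1Cl)C(=O)N(Cc1c(C)cc(C)[nH]c1=O)CC2)C1CCN(C2COC2)CC1`: 78.3 uL/min; 72.7 uL/min (2 entries)
compound 3 `COC(c1cc(Cl)c2c(c1Cl)C(=O)N(Cc1c(C)cc(C)[nH]c1=O)CC2)C1CCOCC1`: 130 uL/min; 129 uL/min (2 entries)

Among the compounds with values here, in an ADME assay on microsomes from liver (Homo sapiens) for metabolic stability, read by LC-MS, using NADPH, with stated times of 10 min and 45 min, tested at 1 uM (a lower number here means slower removal, a higher number faster removal of the compound), compound 1 gives 70.3 uL/min, the only single number among the three; the other two compounds carry several entries each, namely the several entries of compound 2 in this assay, 78.3 uL/min; 72.7 uL/min (2 entries) and (the several entries of compound 3 in this assay, 130 uL/min; 129 uL/min (2 entries)). Compound 4 `Cc1cc(C)c(CN2CCc3c(Cl)cc(-c4c(C)noc4C)c(Cl)c3C2=O)c(=O)[nH]1` has not yet been measured. It differs from compound 1 by a group of 7 heavy atoms (5 carbon, 1 nitrogen, 1 oxygen; one five-membered aromatic ring with 2 hetero atoms) in place of a group of 8 heavy atoms (6 carbon, 2 oxygen; one five-membered non-aromatic ring with 1 hetero atom), on an aromatic carbon. Within the data shown here, no step between two measured compounds is recorded, so the size of this change in this assay is open; a modest rise beyond the scatter seems the more likely direction, though no change at all cannot be excluded. Compound 4 is therefore expected to give 110 uL/min, within 50 uL/min to 250 uL/min. The expected step is then a 1.6-fold higher number from compound 1 to compound 4 (0.19 log units; within the scatter).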

Compound 4, intrinsic clearance in a liver preparation (reported as CLH), per the amount of preparation that the assay uses: 107 uL/min
Compound 4: middle estimate off by 1.0-fold (0.01 log units), on the high side; measured number inside the range.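

In this assay, within the data shown here, the 3,5-dimethyl-1,2-oxazol-4-yl group in place of the earlier group with its five-membered non-aromatic ring gives a 1.5-fold higher number from compound 1 to compound 4 (0.18 log units; within the scatter), the first step that can be read at this aromatic carbon. With the step within the scatter, the two groups cannot be told apart here, although one ring is aromatic and the other is not. Nothing in the data shown gives a cause for this result.

As far as these compounds go, whether an amine or a carboxylic acid on this aromatic carbon would give a step beyond the scatter remains open. So does the part played by each methyl group of the 3,5-dimethyl-1,2-oxazol-4-yl group.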